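Ring nitrogen substituent: cyclopropylmethyl to cyclohexyl

The compounds below may be only part of what the source reports. "The series", "measured", "known", "first", "only" and "open" are said of these compounds alone.

Measured so far in an assay on Huh-7 cells for agonist activity at Bile acid receptor (Homo sapiens), read by a luciferase reporter; on this read-out higher numbers stand for an effect only at larger amounts of compound and lower numbers for an effect already at smaller amounts:
compound 1 `CC(C)c1onc(-c2c(Cl)cccc2Cl)c1COc1ccc(-c2nc3ccc(C(=O)O)cc3n2CC2CC2)cc1`, 19.4 nM
compound 2 `CCC(CC)n1c(-c2ccc(OCc3c(-c4c(Cl)cccc4Cl)noc3C(C)C)cc2F)nc2ccc(C(=O)O)cc21`, 1.3 nM
compound 3 `CCC(CC)n1c(-c2ccc(OCc3c(-c4c(Cl)cccc4Cl)noc3C(C)C)cc2Cl)nc2ccc(C(=O)O)cc21`, 1.6 nM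

Compound 1 stands highest of the three numbers in this assay; compound 3 lies closest to it and compound 2 furthest, both beyond the scatter. Compounds 2 and 3 carry a different group on the aromatic nitrogen and also a halogen on an aromatic carbon, so they differ from compound 1 in two places and their gap to compound 1 cannot be tied to either change alone. Among the measured compounds shown here, the only single step known, a 1.2-fold higher number from compound 2 to compound 3 (0.09 log units; within the scatter), concerns the halogen and not the nitrogen substituent.

Compound 4 `CC(C)c1onc(-c2c(Cl)cccc2Cl)c1COc1ccc(-c2nc3ccc(C(=O)O)cc3n2C2CCCCC2)cc1` differs from compound 1 by cyclohexyl in place of cyclopropylmethyl on an aromatic nitrogen. For the measured compounds named here, no measured step bears directly on this change. Going by the values given here, with no direct precedent, a modest move is expected, at most to a lower number in line with the values of compound 2 and compound 3, which carry another branched group on the same nitrogen. The estimated step is a 2.4-fold lower number from compound 1 to compound 4 (0.38 log units; beyond the scatter); compound 4 is expected to give 8 nM, in the range 2 nM to 30 nM.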

Compound 4, half-maximal effective concentration: 4.21 nM
Compound 4: middle estimate off by 1.9-fold (0.28 log units), on the high side; low and high end bracket the measured number.
By their numbers in this assay, from the lowest: compounds 2 and 3 (each within the scatter of the next); then compound 4; then compound 1.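

In this assay the aromatic nitrogen now has its first single-place step, a 4.6-fold lower number from compound 1 to compound 4 (0.66 log units; beyond the scatter) on exchange of cyclopropylmethyl for cyclohexyl. This position therefore moves the number beyond the scatter with no change of halogen or of anything else on the shared core, and it tolerates a six-membered non-aromatic ring of carbon only placed directly on the nitrogen. No measurement at hand accounts for this step.

Compound 2 and compound 3 each differ from compound 4 in two places, so those gaps cannot be read as the effect of the nitrogen substituent alone. As far as these compounds go, whether the step follows ring size, or the absence of the linking carbon of cyclopropylmethyl, stays open; cyclopentyl, cyclopropyl or a chain carrying an amine on this nitrogen would each test a different part of that question.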